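The source may hold more compounds than are shown below. What is called first, only, known or untested is meant among the compounds shown, and "the series" means these compounds.

Measured compounds:
compound 1 `Cn1nc(Cc2nnc(SCCCCCCCC(=O)Nc3ccc(Cl)cc3Cl)n2CCCO[Si](C)(C)C(C)(C)C)c2ccccc2c1=O`: > 30000 nM in an assay on 32D cells for inhibition of interleukin-15 (Mus musculus), read by resazurin assay, with stated times of 30 min and 2.5 days, in the presence of a further agent that is not named here; a higher number here means a weaker inhibitor, a lower number a stronger inhibitor
compound 2 `Cn1c(Cc2nn(CCCO[Si](C)(C)C(C)(C)C)c(=O)c3ccccc23)nnc1SCCCCCCCC(=O)Nc1ccc(Cl)cc1Cl`: > 30000 nM in this assay

In this assay compound 1 gives > 30000 nM, which is a limit of the assay rather than a number. Compound 2 gives > 30000 nM, again a limit and not a number. Both values sit at the same point, (the limit of > 30000 nM in this assay, at which 2 of the 2 values shown sit), so compound 2 cannot be placed above or below compound 1 on these numbers; it simply stands with compound 1 at the edge of what the assay reports.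

Compound 3 `Cn1c(Cc2nn(CCC(=O)O)c(=O)c3ccccc23)nnc1SCCCCCCCC(=O)Nc1ccc(Cl)cc1Cl` differs from compound 2 by a group of 3 heavy atoms (1 carbon, 2 oxygen; no ring) in place of a group of 9 heavy atoms (7 carbon, 1 oxygen, 1 silicon; no ring), on a saturated chain carbon, two bonds along the chain from an aromatic nitrogen. Among the compounds with values here, no step between measured compounds is available to set the size of such a change, so the expectation rests on compound 2 alone. The step of a number no higher from compound 2 to compound 3 (the limit leaves the size open) is expected to be none beyond the scatter, because compound 2 sits at the limit of > 30000 nM in this assay, at which 2 of the 2 values shown sit. Compound 3 is estimated at 30000 nM, with a range from 5000 nM to 100000 nM, and most likely only a limit again.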

Compound 3, half-maximal inhibitory concentration: > 30000 nM
Compound 3: only a limit was reported (the forecaster's own chance of this, stated with the estimate: 80%); the middle value sits exactly at the limit.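

In this assay compound 3 gives > 30000 nM, a limit and not a number, so no step from compound 2 to compound 3 can be read: the limit of > 30000 nM in this assay, at which 3 of the 3 values shown sit.

The compounds shown leave open how strongly any of them inhibits, and whether the carboxy group of compound 3 makes any difference.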